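Fluoro to cyano swap on the aryl ether of compound 1

The compounds below may be only part of what the source reports. "The series", "measured", "known", "first", "only" and "open" are said of these compounds alone.

Measured compounds in an assay on cells for inhibition of Voltage-dependent T-type calcium channel subunit alpha-1H (Homo sapiens), read by FLIPR and calcium flux, with stated times of 600 s and 300 s; on this read-out lower numbers stand for stronger inhibition and higher numbers for weaker inhibition:
compound 1 `CN(Cc1ccc(OCCCN)cc1)c1nc2ccc(Oc3ccc(F)cc3)cc2s1` — 492000 nM
compound 2 `NCCCOc1ccc(CNc2nc3ccc(Oc4cccc(C(F)(F)F)c4)cc3s2)cc1` — 171000 nM
compound 3 `CN(Cc1ccc(OCCCNC(=N)N)cc1)c1nc2ccc(Oc3cccc(C(F)(F)F)c3)cc2s1` — 771000 nM

Among these three numbers, compound 1 stands second highest. Compound 3 sits nearest to it, with a slightly higher number that lies within the scatter, so no order between compound 1 and compound 3 can be read. Compound 2 shows a lower number, and that gap lies beyond the scatter. All three sit at the weak end of this assay.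

Compound 4 `CN(Cc1ccc(OCCCN)cc1)c1nc2ccc(Oc3ccc(C#N)cc3)cc2s1` has not yet been measured. It differs from compound 1 in a single place: cyano in place of fluoro on an aromatic carbon. The change puts cyano where fluoro stood, on an aromatic carbon of a six-membered aromatic ring of carbon only, para to a large group; cut one bond further out, 4-fluorophenoxy becomes 4-cyanophenoxy.

For the measured compounds named here, no pair of measured compounds isolates this change, so nothing measured speaks to its direction. Compound 2 and compound 3 carry a different group on that ring and differ from compound 1 elsewhere as well, so their values show only the spread of the series. The expected step is a 1.1-fold lower number from compound 1 to compound 4 (0.04 log units; within the scatter), none beyond the scatter. Compound 4 is estimated at 450000 nM, with a range from 150000 nM to 1200000 nM.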

Compound 4, half-maximal inhibitory concentration: 328000 nM
Beside the measured number, compound 4's estimate is 1.4-fold (0.14 log units) above it; the range from low to high includes it.
By their numbers in this assay, from the lowest: compounds 2, 4, 1 and 3 (each within the scatter of the next, the first and the last beyond it).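

In this assay, for the compounds shown here, the swap of fluoro for cyano gives the first direct reading at this position: a 1.5-fold lower number from compound 1 to compound 4 (0.18 log units; within the scatter). No order between the two compounds can be read from this step, so on this pair the position takes a nitrile, with one more heavy atom and one added hydrogen-bond acceptor, without a change that stands clear of the scatter, and compound 4 remains at the weak end of the series at 328000 nM. No supporting measurement bears on this result.

Open, as far as these compounds go, is whether another group on this aromatic carbon, such as a carboxylic acid, a primary amide or a methoxy group, would move the number beyond the scatter, as this single pair covers only fluoro and cyano. Also open, from the compounds shown here alone, is whether the fluoro to cyano swap would give a similar step on a chain ending in a guanidine, as carried by compound 3, rather than on the aminopropoxy chain of compound 1.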